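The source may hold more compounds than are shown below. What is called first, only, known or untested is meant among the compounds shown, and "the series" means these compounds.

Three compounds have been measured in a functional assay on IMR-32 cells (Homo sapiens) for inhibition, read by sulforhodamine B assay, with a stated time of 48 h, tested at 100 uM; a lower number here means less inhibition of growth, a higher number more inhibition of growth at the concentration tested:
Compound 1 `Cc1ccc2occ(C3N=C(c4ccccc4)SS3)c(=O)c2c1` gives 53%.
Compound 2 `O=c1c(C2N=C(c3ccccc3)SS2)coc2ccc(Cl)cc12` gives 92%.
Compound 3 `O=c1c(C2N=C(c3ccccc3)SS2)coc2cc(Cl)c(Cl)cc12` gives 77%.

Compound 2 stands highest of the three in this assay. Its nearest neighbour is compound 3, reached by the step of a number 15 percentage points lower from compound 2 to compound 3 (beyond the scatter), a chloro in place of hydrogen on an aromatic carbon. Furthest away is compound 1, from which compound 2 is reached by the step of a number 39 percentage points higher from compound 1 to compound 2 (beyond the scatter), a chloro in place of methyl on an aromatic carbon.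

Compound 4 `O=c1c(C2N=C(c3ccccc3)SS2)coc2ccc(F)cc12` has not yet been measured. It differs from compound 2 by fluoro in place of chloro on an aromatic carbon. Among the compounds with values here, no measured step exchanges one halogen for another at this carbon. Within the data shown here, the only step that touches this position, a number 39 percentage points higher from compound 1 to compound 2 (beyond the scatter), exchanged methyl for chloro and was large; the step of a number 15 percentage points lower from compound 2 to compound 3 (beyond the scatter), a second chloro at another carbon, was modest and in the other direction. Since fluoro is neither methyl nor chloro, the expectation for compound 4 in this assay is a value between compound 1 and compound 2, closer to compound 2. The expected step from compound 2 is a number 20 percentage points lower from compound 2 to compound 4 (beyond the scatter). Compound 4 is therefore estimated at 72%, with a range from 48% to 92%.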

Compound 4, percent growth inhibition at one concentration: 75%
Compound 4: the middle estimate sits 3 percentage points below what was measured, within the range that was stated.
By their numbers in this assay, from the lowest: compound 1; then compounds 4 and 3 (each within the scatter of the next); then compound 2.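

Exchanging one halogen for the other at this aromatic carbon is not a neutral change: in this assay the result is a number 17 percentage points lower from compound 2 to compound 4 (beyond the scatter), so at this position the top value among the compounds shown goes with chloro and does not extend to fluoro. Fluoro still stands clear of methyl at the same carbon, with a number 22 percentage points higher from compound 1 to compound 4 (beyond the scatter), which places the three groups seen here in the order methyl, fluoro, chloro, each separated from the next by more than the scatter. Nothing available explains why these groups differ in this way.

The compounds shown leave open where hydrogen, bromo, a methoxy group or an amine at this carbon would fall relative to these three, and whether the same order would hold if the phenyl group on the sulfur-containing ring were replaced. Since every compound was read at a single concentration, they also leave open whether these gaps would persist across a range of concentrations.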